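Halogen Placement on the Aryl Oxime and Compound 3

The compounds below may be only part of what the source reports. "The series", "measured", "known", "first", "only" and "open" are said of these compounds alone.

Measured so far:
compound 1, `O/N=C(\CCN1CCN(c2ccccn2)CC1)c1cccc(Cl)c1`: 11.9 nM
compound 2, `O/N=C(\CCN1CCN(c2ccccn2)CC1)c1ccc(Cl)cc1`: 475 nM

Among the measured compounds shown here, in a functional assay on HEK293 cells with D(4) dopamine receptor (Homo sapiens) as the target, read by FLIPR (a lower number here means that less compound is needed, a higher number that more compound is needed for the effect), compound 2 stands with the higher of the two numbers, and the only step yet seen, a 40-fold higher number from compound 1 to compound 2 (1.60 log units; beyond the scatter), separates it from compound 1. Compound 3, `O/N=C(\CCN1CCN(c2ccccn2)CC1)c1cc(F)cc(F)c1`, differs from compound 2 by 3,5-difluorophenyl in place of 4-chlorophenyl on a carbon with a double bond to nitrogen. For the measured compounds named here, that single step is the only one bearing on the change; the 3,5-difluorophenyl of compound 3 resembles the 3-chlorophenyl of compound 1 more than the 4-chlorophenyl of compound 2, though fluorine is not chlorine. Compound 3 is therefore estimated at 45 nM, within 9 nM to 220 nM, meaning an expected 11-fold lower number from compound 2 to compound 3 (1.02 log units; beyond the scatter).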

Compound 3, half-maximal effective concentration: 19.4 nM
Compound 3: middle estimate off by 2.3-fold (0.37 log units), on the high side, within the range that was stated.
By their numbers in this assay, from the lowest: compounds 1 and 3 (each within the scatter of the next); then compound 2.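

In this assay the change away from the 4-chlorophenyl is a large one (a 24-fold lower number from compound 2 to compound 3 (1.39 log units; beyond the scatter)), which shows that this carbon with a double bond to nitrogen does not need chlorine for a low number. Exchanging the 3-chlorophenyl for the 3,5-difluorophenyl (a 1.6-fold higher number from compound 1 to compound 3 (0.21 log units; within the scatter)) leaves the two groups indistinguishable here. Nothing available explains either step. The compounds shown leave open how a bromophenyl or a trifluoromethylphenyl would read at this carbon, and whether a single fluorine would match the two in compound 3.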